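Oxime ether step across two related cores

This account rests on a few compounds, and the source may have more. Where it says the series, first, only, none or still open, it means among the compounds named here.

Compound 1 `CO[C@]1(c2cnc(Sc3ccc(/C(C)=N/O)cc3)s2)CCO[C@@H](C)C1` and compound 2 `CO[C@]1(c2cnc(S(=O)(=O)c3ccc(/C(C)=N/O)cc3)s2)CCO[C@@H](C)C1` share most of their structure but differ in more than one place; the difference between the two cores is not broken down here. In a functional assay (blood) for inhibition, with Homo sapiens as the target (on this read-out lower numbers stand for stronger inhibition and higher numbers for weaker inhibition), compound 1 gives 40 nM, and compound 2 gives 320 nM. Compound 3 `CO[C@]1(c2cnc(S(=O)(=O)c3ccc(/C(C)=N/OCC#N)cc3)s2)CCO[C@@H](C)C1` is derived from compound 2 by cyanomethyl in place of hydrogen on an oxygen, and in this assay compound 3 gives 140 nM; the step is a 2.3-fold lower number from compound 2 to compound 3 (0.36 log units; beyond the scatter). Compound 1 holds the lowest number of the three measured, with compound 3 the nearest and compound 2 the furthest.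

Compound 4 `CO[C@]1(c2cnc(Sc3ccc(/C(C)=N/OCC#N)cc3)s2)CCO[C@@H](C)C1` is not yet measured. It is derived from compound 1 by cyanomethyl in place of hydrogen on an oxygen, the same change as that from compound 2 to compound 3, made on the core of compound 1 rather than the core of compound 2. For the measured compounds named here, the expectation for compound 4 rests on the single measured instance of this change, because a 2.3-fold lower number from compound 2 to compound 3 (0.36 log units; beyond the scatter) is the only step of its kind available. The step for compound 4 is expected to be a 2.2-fold lower number from compound 1 to compound 4 (0.35 log units; beyond the scatter). In this assay compound 4 is estimated at 18 nM, within 8 nM to 45 nM.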

Compound 4, half-maximal inhibitory concentration: 40 nM
Beside the measured number, compound 4's estimate is 2.2-fold (0.35 log units) below it; the measured number falls inside the stated range.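

In this assay, cyanomethyl in place of hydrogen on an oxygen gives no change at the digits printed from compound 1 to compound 4 (within the scatter). Set beside the earlier step on the core of compound 2, the new step cannot be told apart from it: the same change on two cores in this assay, a 2.3-fold lower number (0.36 log units; beyond the scatter) from compound 2 to compound 3 and no change at the digits printed (within the scatter) from compound 1 to compound 4, 2.3-fold (0.36 log units) apart, within the scatter of two such steps. For the compounds shown here, this shows no measurable dependence of the change on the core, but it does not show that the change carries over with a constant size, since each core supplies only one step and the lower number seen on the core of compound 2 does not recur beyond the scatter on the core of compound 1.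

The compounds shown leave open whether other groups on this oxygen, such as methyl, a longer chain ending in a nitrile, or a chain bearing an amine or a carboxylic acid, would behave alike on the two cores. They also leave open whether the same comparison would hold in any other read-out.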